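Swapping Chloro for Methyl on a Cytotoxic Compound

The source may report more compounds than this note shows. Statements on the series, on what has been measured and on what is new or still open speak of the compounds shown alone.

Going by the values given here, in a functional assay on MCF7 cells (Homo sapiens) for cytotoxicity, read by MTT assay, with a stated time of 72 h (on this read-out lower numbers stand for stronger inhibition and higher numbers for weaker inhibition), compound 2 `O=C(CCl)Nc1ccc(C(=O)/C=C/c2ccc(Cl)cc2)cc1` gives 4100 nM, the only true number so far. In this assay compound 1 `COc1ccc(NC(=O)CSC(=S)N[C@H]2CCOC2=O)cc1` gives > 128000 nM, and this is a limit of the test, not a number. With so little measured, compound 2 is the natural starting point for judging a close relative.

That relative is compound 3 `Cc1ccc(/C=C/C(=O)c2ccc(NC(=O)CCl)cc2)cc1`, which has not yet been tested. It differs from compound 2 in one place: methyl in place of chloro on an aromatic carbon. In words, this is methyl in place of chloro on an aromatic carbon, para to a large group, turning 4-chlorophenyl into 4-methylphenyl.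

Among the compounds with values here, no pair of measured compounds shows what this swap does in this assay, so no shift beyond the usual scatter of repeated measurements is expected. The only anchor for the forecast is compound 2 at 4100 nM. The estimated step of a 1.1-fold higher number from compound 2 to compound 3 (0.04 log units; within the scatter) is small and has no firm direction. For compound 3 the expected value is 4500 nM, with an estimated range from 1800 nM to 11000 nM.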

Compound 3, half-maximal inhibitory concentration: 9180 nM
For compound 3 the middle estimate is 2.0-fold (0.31 log units) below the measured one; measured number inside the range.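

Going by these compounds alone, this is the first measured look at what the swap of chloro for methyl does at this spot, on an aromatic carbon para to a large group: in this assay, turning 4-chlorophenyl into 4-methylphenyl gives a 2.2-fold higher number from compound 2 to compound 3 (0.35 log units; beyond the scatter). The position is therefore not indifferent to what sits on it, since exchanging one heavy atom for another moves the number past the usual scatter of repeated measurements, and the direction favours the chloro compound. The step is modest and rests on a single pair, and nothing measured here says why the number moves.

The compounds shown leave open how other groups at this same position would fare, such as an amine, a carboxylic acid or a longer chain like ethyl, so it cannot be said whether chloro is a particularly good choice or simply the better of these two. Also open, from the compounds shown here alone, is whether the same swap would shift the number in the same direction on a different core.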